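Furan-2-yl Amide on a Triazole Dioxolane Piperazine Scaffold

The source may report more compounds than this note shows. Statements on the series, on what has been measured and on what is new or still open speak of the compounds shown alone.

Compound 1 `CCC(=O)Nc1ccc(N2CCN(c3ccc(OC[C@@H]4CO[C@@](Cn5cncn5)(c5ccc(Cl)cc5Cl)O4)cc3)CC2)cc1`: 2550 nM
Compound 2 `O=C(CCCCc1ccccc1)Nc1ccc(N2CCN(c3ccc(OC[C@@H]4CO[C@@](Cn5cncn5)(c5ccc(Cl)cc5Cl)O4)cc3)CC2)cc1`: 2610 nM
Compound 3 `O=C(CCc1ccccc1)Nc1ccc(N2CCN(c3ccc(OC[C@@H]4CO[C@@](Cn5cncn5)(c5ccc(Cl)cc5Cl)O4)cc3)CC2)cc1`: 2060 nM

Three amides of the shared core have been measured in a functional assay on A549 cells (Homo sapiens) for inhibition, read by MTT assay, with a stated time of 48 h; on this read-out higher numbers stand for weaker inhibition and lower numbers for stronger inhibition. Compound 3 stands beside the other two: a 1.2-fold lower number from compound 1 to compound 3 (0.09 log units; within the scatter) and a 1.3-fold lower number from compound 2 to compound 3 (0.10 log units; within the scatter), so the three numbers cannot be separated. The same is true of a 1.0-fold higher number from compound 1 to compound 2 (0.01 log units; within the scatter). The step to compound 4 `O=C(Nc1ccc(N2CCN(c3ccc(OC[C@@H]4CO[C@@](Cn5cncn5)(c5ccc(Cl)cc5Cl)O4)cc3)CC2)cc1)c1ccco1` is furan-2-yl in place of phenethyl on a carbonyl carbon. Of the measured steps, those that change the group on the carbonyl carbon are the ones that bear on it, and all of them lie within the scatter. A further exchange at that position is therefore expected to give no step beyond the scatter, and the estimated step is a 1.1-fold higher number from compound 3 to compound 4 (0.03 log units; within the scatter). For compound 4 the estimate in this assay is 2200 nM, with a range from 1100 nM to 4400 nM.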

Compound 4, half-maximal inhibitory concentration: 10500 nM
Compound 4: the middle estimate sits 4.8-fold (0.68 log units) below what was measured; measured number outside the range, above it.
By their numbers in this assay, from the lowest: compounds 3, 1 and 2 (each within the scatter of the next); then compound 4.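

In this assay, the ethyl, phenethyl and 4-phenylbutyl amides could not be separated, but furan-2-yl on the carbonyl carbon stands apart from all three: a 5.1-fold higher number from compound 3 to compound 4 (0.71 log units; beyond the scatter) and a 4.0-fold higher number from compound 2 to compound 4 (0.60 log units; beyond the scatter) and a 4.1-fold higher number from compound 1 to compound 4 (0.61 log units; beyond the scatter). This position therefore does respond to the group it carries, and here the change weakens inhibition. Nothing at hand explains this difference.

The compounds shown leave open whether a phenyl or thiophen-2-yl group on the carbonyl carbon would track with furan-2-yl or with the chains.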